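Furan to Thiophene at the Amide Tail

The source may report more compounds than this note shows. Statements on the series, on what has been measured and on what is new or still open speak of the compounds shown alone.

Three compounds share one core and differ only in the group on the amide-type nitrogen. Compound 1 `COc1cc(-c2cc(C(=O)O)c3ccccc3n2)ccc1OCC(=O)Nc1ccccc1Cl` gives in an ADME assay on HaCaT cells (Homo sapiens) for inhibition (on this read-out higher numbers stand for weaker inhibition and lower numbers for stronger inhibition), a value of 210000 nM. Compound 2 `COc1cc(-c2cc(C(=O)O)c3ccccc3n2)ccc1OCC(=O)NCc1ccco1` reaches only a limit of the assay in this assay, at > 300000 nM, so its true number is not known. Going by the values given here, the sole measured step, an at least 1.4-fold higher number from compound 1 to compound 2 (0.15 log units; that floor lies within the scatter), rests on that limit (the limit of > 300000 nM in this assay, at which 1 of the 2 values shown sits). Compound 3 `COc1cc(-c2cc(C(=O)O)c3ccccc3n2)ccc1OCC(=O)NCc1cccs1` differs from compound 2 by thiophen-2-yl in place of furan-2-yl on a saturated chain carbon bound to an amide-type nitrogen. Among the compounds with values here, no measured step bears directly on exchanging one five-membered ring for the other; the one step recorded only carried a weak inhibitor past the limit. For compound 3 the expectation is therefore a number close to where compound 2 stands, with no change beyond the scatter, which as a step means a number no higher from compound 2 to compound 3 (the limit leaves the size open). Compound 3 is estimated at 300000 nM, in a range from 120000 nM to 700000 nM, and quite possibly again only a limit.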

Compound 3, half-maximal inhibitory concentration: > 300000 nM
Compound 3: only a limit was reported; the forecaster's own chance of this, stated with the estimate: 60%; the middle value sits exactly at the limit.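

Compound 3 gives > 300000 nM in this assay, which is again a limit of the assay, so sulfur in place of oxygen in the five-membered ring does not yield a readable number. Putting (thiophen-2-yl)methyl in place of 2-chlorophenyl on the amide-type nitrogen gives an at least 1.4-fold higher number from compound 1 to compound 3 (0.15 log units; that floor lies within the scatter). The step from compound 2 to compound 3 cannot be read, because both values are limits: the limit of > 300000 nM in this assay, at which 2 of the 3 values shown sit.

As far as these compounds go, the true numbers of compound 2 and compound 3 stay open, and with them any real difference between furan-2-yl and thiophen-2-yl. Also open, from the compounds shown here alone, is whether an amine or a carboxylic acid on the five-membered ring, or a longer chain in place of the methyl link, would give a number under the limit.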